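The compounds below may be only part of what the source reports. "The series", "measured", "known", "first", "only" and "open" are said of these compounds alone.

For the measured compounds named here, in an ADME assay on J774.A1 cells (Mus musculus) for cytotoxicity, read by MTT assay, with a stated time of 48 h (on this read-out higher numbers stand for lower toxicity in this test and lower numbers for higher toxicity in this test), only two compounds sharing this core have numbers so far. Compound 1 (`O=C(Nc1ccccc1)c1c([N+](=O)[O-])noc1-c1ccc(Cl)cc1Cl`) gives 67300 nM, and compound 2 (`COc1cccc(CNC(=O)c2c([N+](=O)[O-])noc2-c2ccc(Cl)cc2Cl)c1`) gives 61200 nM. These two results cannot be told apart, so compound 2 stands level with compound 1. The step between them is a 1.1-fold lower number from compound 1 to compound 2 (0.04 log units; within the scatter), with 3-methoxybenzyl in place of phenyl on an amide-type nitrogen.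

Compound 3 (`O=C(NCc1cccc(Cl)c1Cl)c1c([N+](=O)[O-])noc1-c1ccc(Cl)cc1Cl`) keeps the core of compound 2 and alters only the group on the amide side: 2,3-dichlorophenyl in place of 3-methoxyphenyl on a saturated chain carbon bound to an amide-type nitrogen. In words, 2,3-dichlorophenyl takes the place of 3-methoxyphenyl on a saturated chain carbon bound to an amide-type nitrogen, which can also be read as 3-methoxybenzyl to 2,3-dichlorobenzyl.

Going by the values given here, no measured step makes this exact swap, so the single step above is only an indirect guide. Since that step stayed within the scatter, no step beyond the scatter is expected here. The expected change is small, estimated as a 1.1-fold lower number from compound 2 to compound 3 (0.05 log units; within the scatter). Compound 3 is estimated at 55000 nM, with an expected range of 25000 nM to 100000 nM.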

Compound 3, half-maximal cytotoxic concentration: 81800 nM
The estimate for compound 3 lay 1.5-fold (0.17 log units) below the measured number; measured number inside the range.
By their numbers in this assay, from the lowest: compounds 2, 1 and 3 (each within the scatter of the next).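

In this assay, putting 2,3-dichlorophenyl in place of 3-methoxyphenyl on a saturated chain carbon bound to an amide-type nitrogen gives a 1.3-fold higher number from compound 2 to compound 3 (0.13 log units; within the scatter). This shows that the position tolerates a swap of the methoxy-bearing ring, which counts one hydrogen-bond acceptor, for a chlorine-bearing ring that counts none, without any change beyond the scatter. The comparison with the plain phenyl amide gives a 1.2-fold higher number from compound 1 to compound 3 (0.08 log units; within the scatter), so all three amide groups shown, phenyl, 3-methoxybenzyl and 2,3-dichlorobenzyl, stand level in this test, and no information is available to explain that.

As far as these compounds go, all three of these groups carry a six-membered aromatic ring of carbon, so it remains open whether the numbers would stay level with a group lacking such a ring, such as a longer alkyl chain, or with one carrying an amine or a carboxylic acid. The rest of the core is the same throughout, so these compounds also say nothing about how changes there, such as replacing the nitro group, would shift the read-out.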